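A few compounds are considered here, and "the series" means these few. Any claim that something is new, unique, unknown or untested is made for them only; others in the source may bear on it.

In a functional assay for activation of Alpha-1A adrenergic receptor (Homo sapiens), read by calcium flux (on this read-out higher numbers stand for an effect only at larger amounts of compound and lower numbers for an effect already at smaller amounts), compound 1 `Cc1nc(-c2ccccc2NCC2=NCCN2)cs1` gives 4.47 nM, the lowest of the two numbers; compound 2 `c1ccc(-c2ccccc2NCC2=NCCN2)nc1` gives 6.76 nM, and the step of a 1.5-fold higher number from compound 1 to compound 2 (0.18 log units; within the scatter) lies within the scatter. Compound 3 `CO/N=C/c1ccccc1NCC1=NCCN1` differs from compound 1 by a group of 4 heavy atoms (2 carbon, 1 nitrogen, 1 oxygen; no ring) in place of a group of 6 heavy atoms (4 carbon, 1 nitrogen, 1 sulfur; one five-membered aromatic ring with 2 hetero atoms), on an aromatic carbon. Within the data shown here, the one measured step, from compound 1 to compound 2, exchanged one aromatic ring for another, whereas here the ring is lost altogether, so no measured step bears closely on it; compound 3 is expected to show a modest rise in this assay, a 2.0-fold higher number from compound 1 to compound 3 (0.30 log units; within the scatter), with an estimate of 9 nM and a range from 2.5 nM to 30 nM.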

Compound 3, half-maximal effective concentration: 51.3 nM
Compound 3: the middle estimate sits 5.7-fold (0.76 log units) below what was measured; the whole stated range lies below it.
By their numbers in this assay, from the lowest: compounds 1 and 2 (each within the scatter of the next); then compound 3.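

In this assay the group without a ring on this aromatic carbon brings an 11-fold higher number from compound 1 to compound 3 (1.06 log units; beyond the scatter) when it replaces 2-methyl-1,3-thiazol-4-yl, and a 7.6-fold higher number from compound 2 to compound 3 (0.88 log units; beyond the scatter) when it replaces pyridin-2-yl. Both steps lie beyond the scatter, whereas the exchange of one aromatic ring for the other stayed within it, so at this position losing the ring counts for more than the choice between these two rings. Nothing at hand bears on the reason for this rise. As far as these compounds go, whether a phenyl ring, a cyclohexyl ring or a simple amine on this carbon would give numbers like those of compound 1 and compound 2 remains open.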